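Phenyl for 2-ethoxyethyl on the shared core

A few compounds are considered here, and "the series" means these few. Any claim that something is new, unique, unknown or untested is made for them only; others in the source may bear on it.

compound 1 `CSc1nc(NC2CCCCC2)c2cccnc2n1` gives 5650 nM
compound 2 `CCOCCNc1nc(SC)nc2ncccc12` gives 7590 nM
compound 3 `CSc1nc(Nc2ccccc2)c2cccnc2n1` is not yet measured

In a functional assay (Nicotiana tabacum) (a lower number here means a stronger inhibitor, a higher number a weaker inhibitor), compound 2 gives 7590 nM and lies within the scatter of compound 1 at 5650 nM so neither stands apart. The change now in view is phenyl in place of 2-ethoxyethyl on a nitrogen on an aromatic ring and it brings one six-membered aromatic ring of carbon only onto that nitrogen. For the measured compounds named here, one measured step bears on this place: a 1.3-fold higher number from compound 1 to compound 2 (0.13 log units; within the scatter) stayed within the scatter when cyclohexyl gave way to 2-ethoxyethyl. Going by the values given here, no measured compound has an aromatic ring on that nitrogen, so the evidence is thin and the range must stay wide. In this assay the estimated step is a 1.2-fold lower number from compound 2 to compound 3 (0.07 log units; within the scatter) and nothing beyond the scatter is expected in either direction. Compound 3 is estimated at 6500 nM with 2200 nM to 19000 nM as its expected range.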

Compound 3, half-maximal inhibitory concentration: 15900 nM
Estimate against measurement, compound 3: 2.4-fold (0.39 log units) below; the range from low to high includes it.
By their numbers in this assay, from the lowest: compounds 1 and 2 (each within the scatter of the next); then compound 3.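

In this assay, this position now responds to the group on the nitrogen: phenyl gives a 2.1-fold higher number from compound 2 to compound 3 (0.32 log units; beyond the scatter) and a 2.8-fold higher number from compound 1 to compound 3 (0.45 log units; beyond the scatter), both modest. Cyclohexyl and 2-ethoxyethyl lie within the scatter of each other, so a ring of carbon alone or an ether chain leaves the two readings apart by no meaningful margin, whereas phenyl, the only aromatic ring of the three on that nitrogen, gives a weaker inhibitor than either. No supporting data bear on why this change raises the number.

As far as these compounds go, with a single aromatic example, it remains open whether the rise belongs to aromatic rings in general or to phenyl alone. A benzyl group or a pyridyl ring on that nitrogen would help separate these two readings.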